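This account rests on a few compounds, and the source may have more. Where it says the series, first, only, none or still open, it means among the compounds named here.

Measured compounds:
compound 1 `Cc1nn(C)c(C)c1S(=O)(=O)N1CCC2(CC1)SCCS2` — in a functional assay on isolated protein for antagonist activity at muscarinic acetylcholine receptor M5 (Homo sapiens), read by calcium flux (on this read-out lower numbers stand for stronger inhibition and higher numbers for weaker inhibition), compound 1 gives > 10000 nM, which is a limit of the assay.
compound 2 `Cc1nn(C)c(C)c1S(=O)(=O)N1CCC2(CCCO2)CC1` — in this assay compound 2 gives > 10000 nM, again a limit of the assay.
compound 3 `Cn1cc(S(=O)(=O)N2CCC3(CC2)OCCS3)cn1` — in this assay compound 3 gives > 10000 nM, also a limit of the assay.

Compound 3 therefore stands only at a limit, and the two further values shown are limits as well; all three sit at the limit of > 10000 nM in this assay, at which 3 of the 3 values shown sit. For the measured compounds named here, no step between measured compounds can be sized from these numbers, since none of them is a number.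

Compound 4 `Cc1c(S(=O)(=O)N2CCC3(CC2)OCCS3)cnn1C` differs from compound 3 by methyl in place of hydrogen on an aromatic carbon. With every measured value a limit, there is nothing to anchor the size of this change. The expectation in this assay is no step beyond the scatter, the estimated step being a step that the limit leaves unreadable from compound 3 to compound 4. For compound 4 the expected value in this assay is 15000 nM, with a range from 3000 nM to 60000 nM, and most likely the assay will again report only a limit.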

Compound 4, half-maximal inhibitory concentration: > 10000 nM
Compound 4 was reported as a limit (the forecaster's own chance of this, stated with the estimate: 80%); the middle value lies beyond the limit too.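

For the compounds shown here, compound 3 and compound 4 both stand only at a limit of the assay, so no step between them can be read. The compounds shown leave open whether anything in this series gives a measurable value in this assay and what methyl in place of hydrogen on an aromatic carbon contributes.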